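Chloro for trifluoromethyl on the urea aryl ring

The source may hold more compounds than are shown below. What is called first, only, known or untested is meant among the compounds shown, and "the series" means these compounds.

Compound 1 `C[C@@H](NC(=O)Nc1ccccc1C(F)(F)F)c1ccccc1`: 95%
Compound 2 `C[C@H](NC(=O)Nc1ccccc1C(F)(F)F)c1ccccc1`: 98%
Compound 3 `C[C@@H](NC(=O)Nc1cccc(F)c1)c1ccccc1`: 95%

In an ADME assay on the whole organism with Oryza sativa as the target, tested at 1 uM (on this read-out higher numbers stand for a weaker effect at the one concentration tested and lower numbers for a stronger effect), compound 2 gives 98%. Within the data shown here, its only measured step is a number 3 percentage points higher from compound 1 to compound 2 (within the scatter), a step within the scatter, and compound 3 shows a value close to it. Compound 4 `C[C@H](NC(=O)Nc1ccccc1Cl)c1ccccc1` differs from compound 2 by chloro in place of trifluoromethyl on an aromatic carbon. No measured step changes this position of the ring; the one available step, a number 3 percentage points higher from compound 1 to compound 2 (within the scatter), concerns only configuration, as shown by the fact that compounds 1 and 2 differ only in the configuration as drawn, and the value of compound 3 adds no step. The three numbers cluster at a weak effect, so no step beyond the scatter is expected for compound 4 in this assay, its estimated step being a number 3 percentage points lower from compound 2 to compound 4 (within the scatter). Compound 4 is expected to give 95%, in the range 85% to 100%.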

Compound 4, a percentage reported as activity, at one concentration (the size of the read-out at that concentration, not a potency): 104%
For compound 4 the middle estimate is 9 percentage points below the measured one; the whole stated range lies below it.
By their numbers in this assay, from the lowest: compounds 1, 3, 2 and 4 (each within the scatter of the next).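

Among these compounds, on the aromatic carbon ortho to a large group, chloro in place of trifluoromethyl is the first measured change at this position, and this assay shows a number 6 percentage points higher from compound 2 to compound 4 (within the scatter) for this swap. One heavy atom thus takes the place of four while the two compounds stay within the scatter of each other. Nothing in the information available bears on this step.
Going by these compounds, whether an amine or a carboxylic acid at this position would give a step beyond the scatter remains open. So does whether chloro gives the same result with the stereocentre drawn the other way.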